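This account rests on a few compounds, and the source may have more. Where it says the series, first, only, none or still open, it means among the compounds named here.

Compound 1, `CCn1cc(-c2nc3ccccc3[nH]2)c(=O)c2cc(F)c(N3CCN(C)CC3)cc21`, gives only a limit of the assay in a functional assay on A2780 cells (Homo sapiens) for cytotoxicity, read by MTT assay, with a stated time of 48 h; a lower number here means a stronger inhibitor, a higher number a weaker inhibitor: > 5010000 nM.
Compound 2, `CCn1cc(-c2nc3ccccc3s2)c(=O)c2cc(F)c(N3CCNCC3)cc21`, gives in this assay a value of 11300 nM.

Among the measured compounds shown here, compound 2 holds the only real number among the two values shown; the other entry is a limit, (the limit of > 5010000 nM in this assay, at which 1 of the 2 values shown sits), and nothing more can be read from it. The unmeasured compound 3, `CCn1cc(-c2nc3ccccc3s2)c(=O)c2cc(F)c(N3CCN(C)CC3)cc21`, keeps the shared core of compound 2 and differs from it in one place: methyl in place of hydrogen on an amine nitrogen in a ring. For the measured compounds named here, no step between two measured compounds is available to show how this change acts, so the expectation rests on the single value of compound 2 alone. Compound 3 is therefore expected to sit close to compound 2, with a step of a 1.3-fold higher number from compound 2 to compound 3 (0.12 log units; within the scatter) that is expected to be small and undirected, not clearly beyond the scatter. For compound 3 the estimate in this assay is 15000 nM, expected to fall between 4000 nM and 60000 nM.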

Compound 3, half-maximal inhibitory concentration: 114000 nM
Compound 3: the middle estimate sits 7.6-fold (0.88 log units) below what was measured, outside the stated range (above it).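

In this assay, the amine nitrogen of the piperazin-1-yl ring proves sensitive to a small change: methyl in place of hydrogen there gives a 10-fold higher number from compound 2 to compound 3 (1.00 log units; beyond the scatter). With the 4-methylpiperazin-1-yl group kept, 1,3-benzothiazol-2-yl in place of 1H-benzimidazol-2-yl on the aromatic carbon gives an at least 43-fold lower number from compound 1 to compound 3 (1.64 log units; beyond the scatter). That step gives a bound and not an exact size, as compound 1 gives only a limit of the assay: the limit of > 5010000 nM in this assay, at which 1 of the 3 values shown sits.

The compounds shown leave open whether this weakening belongs to methyl alone or to any group on that ring nitrogen, which an ethyl or acetyl group there would help to settle. As far as these compounds go, it also remains open whether hydrogen on that nitrogen would have the same effect with 1H-benzimidazol-2-yl in place of 1,3-benzothiazol-2-yl.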